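Tert-butyl on the pendant aryl: a second test

This account rests on a few compounds, and the source may have more. Where it says the series, first, only, none or still open, it means among the compounds named here.

Measured compounds in a functional assay on ACHN cells (Homo sapiens) for cytotoxicity, read by sulforhodamine B assay, tested at 10 uM; on this read-out higher numbers stand for more inhibition at the one concentration tested (going by the name of the read-out) and lower numbers for less inhibition:
compound 1, `CC(=O)OC[C@H]1O[C@@H](n2cc(-c3cc(-c4ccc(C(C)(C)C)cc4)no3)c(=O)[nH]c2=O)C[C@@H]1OC(C)=O`, gives 74.7%
compound 2, `CC(=O)OC[C@H]1O[C@@H](n2cc(-c3cc(-c4ccccc4)no3)c(=O)[nH]c2=O)C[C@@H]1OC(C)=O`, gives 97.6%
compound 3, `CC(=O)OC[C@H]1O[C@@H](n2cc(-c3cn(Cc4ccccc4)nn3)c(=O)[nH]c2=O)C[C@@H]1OC(C)=O`, gives 99%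

Compound 1 and compound 2 share one core; compound 3 carries another, and the difference between the two cores is not broken down here. Compound 2 and compound 3 sit within the scatter of each other.

One change, (tert-butyl in place of hydrogen on an aromatic carbon), has already been made on the first core and gave a number 22.9 percentage points lower from compound 2 to compound 1 (beyond the scatter). The same change, (tert-butyl in place of hydrogen on an aromatic carbon), gives compound 4, `CC(=O)OC[C@H]1O[C@@H](n2cc(-c3cn(Cc4ccc(C(C)(C)C)cc4)nn3)c(=O)[nH]c2=O)C[C@@H]1OC(C)=O`, still to be measured. The place of the change reads the same in both cases.

For compound 4, a step like a number 21 percentage points lower from compound 3 to compound 4 (beyond the scatter) is expected, because the earlier step of a number 22.9 percentage points lower from compound 2 to compound 1 (beyond the scatter) was modest and beyond the scatter. The value of compound 4 is therefore estimated at 78%.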

Compound 4, a percentage reported as inhibition, at one concentration (the size of the read-out at that concentration, not a potency): 97.2%
Beside the measured number, compound 4's estimate is 19.2 percentage points below it; the whole stated range lies below it.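

In this assay, tert-butyl in place of hydrogen on an aromatic carbon gives a number 1.8 percentage points lower from compound 3 to compound 4 (within the scatter), so the step seen on the first core does not carry over to the second: the same change on two cores in this assay, a number 22.9 percentage points lower (beyond the scatter) from compound 2 to compound 1 and a number 1.8 percentage points lower (within the scatter) from compound 3 to compound 4, 21.1 percentage points apart, beyond the scatter of two such steps Within these two pairs, the loss on the core of compound 2 therefore does not hold as a general penalty for this change. Among the compounds shown here, the pairs do not show why the steps part, nor how potency moves, as the read-out gives the size of inhibition at one concentration, and only two cores are compared.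

Still open, from the compounds shown here alone, is how other groups in the same place behave, such as an amine or a carboxylic acid. A third core would test whether either step is the more typical one.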